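A Nitrothiazole Swap on the Amide Nitrogen

A few compounds are considered here, and "the series" means these few. Any claim that something is new, unique, unknown or untested is made for them only; others in the source may bear on it.

Measured so far in an ADME assay on NIH3T3 cells (Mus musculus) for cytotoxicity, read by MTT assay, with a stated time of 24 h; a lower number here means a stronger inhibitor, a higher number a weaker inhibitor:

- Compound 1 `O=C(CSc1nnc(COc2ccc3c(c2)CCCC3)o1)Nc1nc2ccccc2s1`: 96700 nM
- Compound 2 `COc1ccc2nc(NC(=O)CSc3nnc(COc4ccc5c(c4)CCCC5)o3)sc2c1`: 94300 nM

Compound 2, at 94300 nM, stands level with compound 1, and the two values lie within the scatter of each other. The next compound to be tested in this assay is compound 3 `O=C(CSc1nnc(COc2ccc3c(c2)CCCC3)o1)Nc1ncc([N+](=O)[O-])s1`. It carries 5-nitro-1,3-thiazol-2-yl in place of 6-methoxy-1,3-benzothiazol-2-yl on an amide-type nitrogen.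

For the measured compounds named here, only one measured step bears on this change. Methoxy in place of hydrogen on an aromatic carbon gave a 1.0-fold lower number from compound 1 to compound 2 (0.01 log units; within the scatter). That step altered the same group on the amide-type nitrogen, yet it was far smaller as a structural change than the one now made. Going by the values given here, no measured compound carries a nitro group or a lone thiazole, so the data give only weak guidance. With that single flat step as the basis, no shift beyond the scatter is expected, though the uncertainty is wide. The estimated step is a 1.2-fold lower number from compound 2 to compound 3 (0.07 log units; within the scatter). For compound 3 the expected value is 80000 nM, with an estimated range from 30000 nM to 170000 nM.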

Compound 3, half-maximal inhibitory concentration: > 403000 nM
Compound 3: no number, only a limit (the forecaster's own chance of this, stated with the estimate: 15%); middle value at least 5.0-fold (0.70 log units) from the limit.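

In this assay, the group on the amide-type nitrogen can shift the read-out beyond the scatter, which the methoxy step alone had not shown. Putting 5-nitro-1,3-thiazol-2-yl in place of 6-methoxy-1,3-benzothiazol-2-yl gave an at least 4.2-fold higher number from compound 2 to compound 3 (0.63 log units; beyond the scatter), and putting it in place of 1,3-benzothiazol-2-yl gave an at least 4.1-fold higher number from compound 1 to compound 3 (0.61 log units; beyond the scatter), so both comparisons point the same way, towards a weaker inhibitor. The value of compound 3 is a limit and not a number, so these steps fix a direction and a smallest size but not a full size: the limit of > 403000 nM in this assay, at which 1 of the 3 values shown sits.

The compounds shown leave open which part of the change carries the step, since the six-membered aromatic ring of carbon only leaves and the nitro group enters in the same move. From the compounds shown here alone, a plain 1,3-thiazol-2-yl group on this nitrogen, or a nitro group on the 1,3-benzothiazol-2-yl group, would separate the two, and whether an amine in place of the nitro group would give the same result also remains unknown.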